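Aryl for cyclopropyl on the ring amide nitrogen

A few compounds are considered here, and "the series" means these few. Any claim that something is new, unique, unknown or untested is made for them only; others in the source may bear on it.

Compound 1 `O=C1COc2ccc(-c3cccc(NS(=O)(=O)c4ccc(F)cc4)c3)cc2N1C1CC1` carries cyclopropyl on the amide-type nitrogen of the shared core. In a functional assay on MCF7 cells (Homo sapiens) for antiproliferative activity, read by MTT assay, with a stated time of 72 h (a lower number here means a stronger inhibitor, a higher number a weaker inhibitor), compound 1 gives only a limit, > 40000 nM, so its position on the scale is not a number. Where it stands: the limit of > 40000 nM in this assay, at which 1 of the 2 values shown sits. Going by the values given here, the one measured companion, compound 2 `COc1ncc(-c2ccc3c(c2)N(C2CCCCC2)C(=O)CO3)cc1NS(=O)(=O)c1ccc(F)cc1`, differs at more than one place and gives 30100 nM in this assay; no single step between the two can be drawn.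

Compound 3 `COc1ccc(N2C(=O)COc3ccc(-c4cccc(NS(=O)(=O)c5ccc(F)cc5)c4)cc32)cc1` is to be measured in this assay. Its change from compound 1: 4-methoxyphenyl in place of cyclopropyl on an amide-type nitrogen in a ring. Among the compounds with values here, no measured step matches this change, so any direction rests on nothing measured here. The step from compound 1 to compound 3 is expected to be modest and toward stronger inhibition, an at least 2.0-fold lower number from compound 1 to compound 3 (0.30 log units; that floor lies within the scatter), with wide uncertainty. For compound 3 the estimate in this assay is 20000 nM, with a range from 5000 nM to 60000 nM, and a fair chance that only a limit is reported again.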

Compound 3, half-maximal inhibitory concentration: 32400 nM
Beside the measured number, compound 3's estimate is 1.6-fold (0.21 log units) below it; the range from low to high includes it.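

In this assay, the amide-type nitrogen in a ring carries 4-methoxyphenyl in compound 3, which gives a number on the scale, 32400 nM, and so the larger aryl group at this position still yields a reading rather than a limit. The change reads as an at least 1.2-fold lower number from compound 1 to compound 3 (0.09 log units; that floor lies within the scatter), so the data show a floor only and no gain beyond the scatter. Compound 1 remains a limit, which leaves the true size of the step unknown: the limit of > 40000 nM in this assay, at which 1 of the 3 values shown sits.

Open, going by these compounds, is whether any group on this nitrogen moves the number well beyond the scatter, since a single step with a limit at one end cannot set a trend. Also open, on these data alone, is how an aminoethyl chain, or a phenyl ring bearing a carboxylic acid, would read at this position.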